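Swapping methoxy for chloro on a cinnamamide benzothiazinone

The source may report more compounds than this note shows. Statements on the series, on what has been measured and on what is new or still open speak of the compounds shown alone.

Of the compounds shown here, three have been tested in an assay on mitochondria (strain Sprague-Dawley) for inhibition of Amine oxidase [flavin-containing] B (Rattus norvegicus), read by fluorescence and Amplex Red, with stated times of 30 min and 45 min; on this read-out higher numbers stand for weaker inhibition and lower numbers for stronger inhibition. Compound 1, `COc1cccc(/C=C/C(=O)Nc2nc3ccccc3c(=O)s2)c1`, gives 281 nM in this assay. Compound 2, `COc1cccc(CCCC(=O)Nc2nc3ccccc3c(=O)s2)c1`, gives 1300 nM in this assay, and compound 3, `O=C(CCCc1cccc(Cl)c1)Nc1nc2ccccc2c(=O)s1`, gives 6880 nM there. Compound 1 and compound 2 share a core but differ in a way that is not broken down here; their values alone show that compound 1 sits lower. Compound 2 and compound 3 differ in one place only, (chloro in place of methoxy on an aromatic carbon), and this change produced a 5.3-fold higher number from compound 2 to compound 3 (0.72 log units; beyond the scatter).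

Compound 4, `O=C(/C=C/c1cccc(Cl)c1)Nc1nc2ccccc2c(=O)s1`, is not yet measured. It differs from compound 1 by chloro in place of methoxy on an aromatic carbon, the same change as from compound 2 to compound 3, at a place described in the same words. Because the earlier step was a 5.3-fold higher number from compound 2 to compound 3 (0.72 log units; beyond the scatter), compound 4 is expected to give a weaker result than compound 1, by about a 5.0-fold higher number from compound 1 to compound 4 (0.70 log units; beyond the scatter). For the measured compounds named here, the estimate for compound 4 in this assay is therefore 1400 nM, with a likely range from 500 nM to 4000 nM, resting on only that one earlier step.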

Compound 4, half-maximal inhibitory concentration: 815 nM
Compound 4: the middle estimate sits 1.7-fold (0.23 log units) above what was measured; the range from low to high includes it.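

In this assay the change from 3-methoxyphenyl to 3-chlorophenyl on the core of compound 1 gave a 2.9-fold higher number from compound 1 to compound 4 (0.46 log units; beyond the scatter) and so weakened inhibition, as it had on the other core. Set side by side, the two steps point the same way and cannot be told apart in size: the same change on two cores in this assay, a 5.3-fold higher number (0.72 log units; beyond the scatter) from compound 2 to compound 3 and a 2.9-fold higher number (0.46 log units; beyond the scatter) from compound 1 to compound 4, 1.8-fold (0.26 log units) apart, within the scatter of two such steps. This suggests that the change carries over between these two cores, but it rests on a single pair of steps, so it does not show that the change would behave alike on any further core, and it gives no explanation of why chloro reads weaker than methoxy.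

The compounds shown carry only methoxy or chloro on that aromatic carbon, so an amine, a carboxylic acid or a fluoro group there remains open. Also open, going by these compounds, is whether the same step would hold with a longer chain on the amide carbonyl.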